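This account rests on a few compounds, and the source may have more. Where it says the series, first, only, none or still open, it means among the compounds named here.

Values in a functional assay on A549 cells (Homo sapiens) for antiproliferative activity, read by sulforhodamine B assay, with a stated time of 48 h; a higher number here means a weaker inhibitor, a lower number a stronger inhibitor:
compound 1 `COc1ccc2nc(-c3ccc(N/C=C\C(=O)c4cc(OC)c(OC)c(OC)c4)c(C)c3)sc2c1`: 11100 nM
compound 2 `COc1ccc2nc(-c3ccc(N/C=C\C(=O)c4cc(OC)c(OC)c(OC)c4)cc3)sc2c1`: 12100 nM
compound 3 `COc1ccc2nc(-c3ccc(N/C=C\C(=O)c4cc(OC)c(OC)c(OC)c4Br)c(C)c3)sc2c1`: 6400 nM

Compound 3, at 6400 nM, stands within the usual scatter of both compound 1 and compound 2, so these three numbers cannot be told apart. Compound 4 `COc1ccc2nc(-c3ccc(N/C=C\C(=O)c4cc(OC)c(OC)c(OC)c4Br)cc3)sc2c1` has not yet been measured. It differs from compound 3 by one small edit, hydrogen in place of methyl on an aromatic carbon.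

For the measured compounds named here, the closest precedent is the same edit made on a molecule without the bromo group, which gave a 1.1-fold higher number from compound 1 to compound 2 (0.04 log units; within the scatter). The bromo group itself also bears on the question, since adding it gave a 1.7-fold lower number from compound 1 to compound 3 (0.24 log units; within the scatter). Neither step rises above the scatter, so no step beyond the scatter is expected in this assay. The expected result is a 1.1-fold higher number from compound 3 to compound 4 (0.04 log units; within the scatter), a change too small to read a direction into. For compound 4 the estimated value is 7000 nM, with an expected range of 3500 nM to 13500 nM.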

Compound 4, half-maximal inhibitory concentration: 6000 nM
Estimate against measurement, compound 4: 1.2-fold (0.07 log units) above; the range from low to high includes it.
By their numbers in this assay, from the lowest: compounds 4, 3, 1 and 2 (each within the scatter of the next).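

In this assay, hydrogen in place of methyl on this aromatic carbon, ortho to a large group, has now also been tried with the bromo group present, giving a 1.1-fold lower number from compound 3 to compound 4 (0.03 log units; within the scatter) and matching the earlier step on the core without bromo: the same change on two cores in this assay, a 1.1-fold higher number (0.04 log units; within the scatter) from compound 1 to compound 2 and a 1.1-fold lower number (0.03 log units; within the scatter) from compound 3 to compound 4, 1.2-fold (0.07 log units) apart, within the scatter of two such steps. The bromo group has likewise now been added to a second core, the one without the methyl, giving a 2.0-fold lower number from compound 2 to compound 4 (0.30 log units; within the scatter) and again matching the earlier step: the same change on two cores in this assay, a 1.7-fold lower number (0.24 log units; within the scatter) from compound 1 to compound 3 and a 2.0-fold lower number (0.30 log units; within the scatter) from compound 2 to compound 4, 1.2-fold (0.07 log units) apart, within the scatter of two such steps. Neither edit rises above the scatter on either core, so neither the methyl nor the bromo group separates these four compounds.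

As far as these compounds go, whether another group in the methyl's place, such as an amine, a carboxylic acid or a longer chain, would give a step beyond the scatter remains open. The same question stands for a chloro or a methoxy group where the bromo sits.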